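This account rests on a few compounds, and the source may have more. Where it says the series, first, only, none or still open, it means among the compounds named here.

Working notes on the series. Among the measured compounds shown here, in a functional assay on MCF7 cells (Homo sapiens) for cytotoxicity, read by MTT assay, with a stated time of 72 h (a lower number here means a stronger inhibitor, a higher number a weaker inhibitor), compound 1 (`Cc1ccc2[nH]c(-n3cccn3)c(C3=C(Br)C(=O)NC3=O)c2c1`) gives 15000 nM as the only number so far. Compound 2 (`COc1ccc2[nH]c3c(c4c(c5ccnn53)C(=O)NC4=O)c2c1`) carries the entry "not determined" (no result reported) and offers no comparison, so compound 1 cannot yet be ranked against any other compound. In this assay compound 3 (`O=C1NC(=O)C(c2c(-n3cccn3)[nH]c3ccccc23)=C1Br`) remains unmeasured.

The structural change from compound 1 to compound 3 is hydrogen in place of methyl on an aromatic carbon and amounts to hydrogen in place of methyl on an aromatic carbon. The rest of the structure stays the same. For the measured compounds named here, no measured pair tests this change, so the expectation rests on compound 1 alone, at 15000 nM in a single reading. In this assay no step beyond the usual scatter is expected, and a single number gives no basis for favouring either direction. The estimated step of a 1.2-fold higher number from compound 1 to compound 3 (0.08 log units; within the scatter) is therefore small and is expected to stay within the scatter. Compound 3 is estimated at 18000 nM with an expected range from 7000 nM to 45000 nM in the measurement still to come.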

Compound 3, half-maximal inhibitory concentration: 27000 nM
Compound 3: the middle estimate sits 1.5-fold (0.18 log units) below what was measured; the measured number falls inside the stated range.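

In this assay, the series now has its first measured step, and it falls on an aromatic carbon of the six-membered aromatic ring of carbon only: hydrogen in place of methyl gives a 1.8-fold higher number from compound 1 to compound 3 (0.26 log units; within the scatter) and so stays within the usual scatter. Compound 1 alone could not show whether the methyl group at this place counted for anything in the read-out; this single pair shows that its loss cannot be told apart from repeat variation, with the rest of the shared core held the same. No measurement on hand explains the outcome, and this one pair sets no trend for other groups at this place.

The compounds shown leave open whether anything other than methyl or hydrogen at this carbon would move the number beyond the scatter, for instance an amine, a carboxylic acid or a longer chain such as propyl. They also leave open whether changes elsewhere on the shared core, such as replacing the bromine with chlorine, would separate from compound 1 in this assay at all.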